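Thiazole-fused core series: liver microsome half-life notes

The source may report more compounds than this note shows. Statements on the series, on what has been measured and on what is new or still open speak of the compounds shown alone.

Measured so far:
compound 1 `CCCNC(=O)[C@@H]1C[C@H]2CCC[C@@H](C1)[C@@H]2NC(=O)c1cc2scnc2n1Cc1ccc(OC)cc1`: 0.743 h
compound 2 `CCCNC(=O)C1CCN(C(=O)c2cc3scnc3n2Cc2ccc(OC)cc2)CC1`: 0.462 h
compound 3 `CCCNC(=O)[C@@H]1C[C@H]2CCC[C@@H](C1)[C@@H]2NC(=O)c1cc2sc(-c3ccccc3)nc2n1Cc1ccc(OC)cc1`: 0.453 h

In an ADME assay on microsomes from liver (Homo sapiens) for metabolic stability (on this read-out higher numbers stand for a longer-lived compound and lower numbers for a shorter-lived compound), compound 1 gives 0.743 h. Compound 3 `CCCNC(=O)[C@@H]1C[C@H]2CCC[C@@H](C1)[C@@H]2NC(=O)c1cc2sc(-c3ccccc3)nc2n1Cc1ccc(OC)cc1` carries the change (phenyl in place of hydrogen on an aromatic carbon), and in this assay this made a step of a 1.6-fold lower number from compound 1 to compound 3 (0.21 log units; within the scatter). Compound 2 `CCCNC(=O)C1CCN(C(=O)c2cc3scnc3n2Cc2ccc(OC)cc2)CC1` has a different core from compound 1; the difference between the two cores is not broken down here. In this assay compound 2 gives 0.462 h, and the values of compound 2 and compound 3 lie close together.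

Compound 4 `CCCNC(=O)C1CCN(C(=O)c2cc3sc(-c4ccccc4)nc3n2Cc2ccc(OC)cc2)CC1` is not yet measured. It differs from compound 2 by phenyl in place of hydrogen on an aromatic carbon, the same change as from compound 1 to compound 3, at the same place. Because the earlier step was a 1.6-fold lower number from compound 1 to compound 3 (0.21 log units; within the scatter), a step of similar size, a 1.6-fold lower number from compound 2 to compound 4 (0.20 log units; within the scatter), is expected from compound 2 to compound 4. Compound 4 is therefore estimated at 0.29 h in this assay, between 0.15 h and 0.6 h.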

Compound 4, half-life: 0.68 h
Beside the measured number, compound 4's estimate is 2.3-fold (0.37 log units) below it; measured number outside the range, above it.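

In this assay, phenyl in place of hydrogen on an aromatic carbon gives a 1.5-fold higher number from compound 2 to compound 4 (0.17 log units; within the scatter). Set beside the same change on the core of compound 1, the two steps cannot be told apart: the same change on two cores in this assay, a 1.6-fold lower number (0.21 log units; within the scatter) from compound 1 to compound 3 and a 1.5-fold higher number (0.17 log units; within the scatter) from compound 2 to compound 4, 2.4-fold (0.38 log units) apart, within the scatter of two such steps. This shows no dependence on the core for this change, but with both steps within the scatter, it does not show that phenyl has a real effect on either core or that a step of any given size carries from one core to the other.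

Phenyl is the only group compared at this place on the two cores. From the compounds shown here alone, whether an amine or a carboxylic acid on the same carbon would give steps that carry between the cores remains open.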